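The compounds below may be only part of what the source reports. "The series", "measured", "known", "first", "only" and "open" are said of these compounds alone.

Working notes on the series. In an ADME assay on Huh-7 cells (Homo sapiens) for cytotoxicity, with a stated time of 72 h (on this read-out lower numbers stand for higher toxicity in this test and higher numbers for lower toxicity in this test), compound 1 `CC(C)CCn1nc(C2CCCC2)c(O)c(C2=NS(=O)(=O)c3cc(NS(C)(=O)=O)ccc3N2)c1=O` gives only a limit, > 1000 nM. Compound 2 `CC(C)CCn1nc(CC2=CCCC2)c(O)c(C2=NS(=O)(=O)c3cc(NS(C)(=O)=O)ccc3N2)c1=O` also gives only a limit, > 33000 nM. Compound 3 `CC(C)CCn1nc(CC(C)C)c(O)c(C2=NS(=O)(=O)c3cc(NS(C)(=O)=O)ccc3N2)c1=O` likewise gives only a limit, > 1000 nM. No number is therefore available for compound 3, which shares (the limit of > 1000 nM in this assay, at which 2 of the 3 values shown sit), and no value can be ranked against it.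

The next change leads to compound 4 `CC(C)CCn1nc(CCC(F)(F)F)c(O)c(C2=NS(=O)(=O)c3cc(NS(C)(=O)=O)ccc3N2)c1=O`: 2,2,2-trifluoroethyl in place of isopropyl on a saturated chain carbon bound to an aromatic carbon. In words, this is 2,2,2-trifluoroethyl in place of isopropyl on a saturated chain carbon bound to an aromatic carbon.

The measured steps bearing on it are a step that the two limits leave unreadable from compound 2 to compound 3, a step that the two limits leave unreadable from compound 1 to compound 3 and a step that the two limits leave unreadable from compound 1 to compound 2. None has a readable size, so none supplies a size or direction to carry over. No step beyond the scatter is expected in this assay, and another limit is the likely report.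

The estimated change is a step that the limit leaves unreadable from compound 3 to compound 4.

For compound 4 the expected value is 30000 nM, with an estimated range of 5000 nM to 100000 nM.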

Compound 4, half-maximal cytotoxic concentration: > 33000 nM
Compound 4: only a limit was reported; the forecaster's own chance of this, stated with the estimate: 85%; middle value at least 1.1-fold (0.04 log units) away from the limit.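

In this assay, for the compounds shown here, compound 4 gives only a limit, > 33000 nM, so no step linking it to compound 1, compound 2 or compound 3 can be read. The compounds shown leave open whether these four differ at all in this assay: every value is a limit.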